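The compounds below may be only part of what the source reports. "The series", "measured", "known", "first", "only" and "open" are said of these compounds alone.

Measured compounds: compound 1 `CCOc1ccnc(Nc2ccc(Cl)c(OCC=C(C)C)c2)n1` and compound 2 `CC(C)=CCOc1cc(Nc2ncccn2)ccc1Cl`.

In an ADME assay on MT2 cells (Homo sapiens) for cytotoxicity (a lower number here means that less compound is tolerated, a higher number that more compound is tolerated), compound 1 gives 19000 nM, while compound 2 gives 2500 nM. Going by the values given here, compound 2 thus stands at the lowest of the two numbers; the single measured step, a 7.6-fold lower number from compound 1 to compound 2 (0.88 log units; beyond the scatter), comes from hydrogen in place of ethoxy on an aromatic carbon of the shared core.

Compound 3 `C/C=C/COc1cc(Nc2ncccn2)ccc1Cl` differs from compound 2 at another place: prop-1-en-1-yl in place of 2-methylprop-1-en-1-yl on a saturated chain carbon bound to an oxygen on an aromatic ring. Among the compounds with values here, the one measured step concerns the core and not the chain bound to the oxygen on the aromatic ring, so no measured step bears directly on this change. With nothing in the data pointing either way, only a small shift in this assay is expected, if any beyond the scatter, a 1.4-fold higher number from compound 2 to compound 3 (0.15 log units; within the scatter). Compound 3 is therefore estimated at 3500 nM, with a likely range from 1500 nM to 9000 nM.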

Compound 3, half-maximal cytotoxic concentration: 31000 nM
Beside the measured number, compound 3's estimate is 8.9-fold (0.95 log units) below it, and the stated range ends below it.
By their numbers in this assay, from the lowest: compound 2; then compounds 1 and 3 (each within the scatter of the next).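

The chain bound to the oxygen on the aromatic ring matters in this assay: but-2-en-1-yl in place of 3-methylbut-2-en-1-yl gives a 12-fold higher number from compound 2 to compound 3 (1.09 log units; beyond the scatter) as a large step, although the change is confined to the chain and enters no ring, hydrogen-bond donor, hydrogen-bond acceptor or net charge. The core is therefore no longer the only place shown to move this number beyond the scatter, as it did with a 7.6-fold lower number from compound 1 to compound 2 (0.88 log units; beyond the scatter) in the shared series. Nothing at hand explains the size of the new step.

From the compounds shown here alone, whether the number follows the length or branching of this chain remains open, and a saturated butyl group, a longer chain or a chain ending in an amine would bear on that. Also open, going by these compounds, is whether the same chain change has a similar effect with ethoxy on the core, as in compound 1.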